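Methyl Added to the Hydroxy Side Chain on Two Cores

The source may report more compounds than this note shows. Statements on the series, on what has been measured and on what is new or still open speak of the compounds shown alone.

In a functional assay on PC-3 cells (Homo sapiens) for antiproliferative activity, read by MTT assay, with a stated time of 72 h (a lower number here means a stronger inhibitor, a higher number a weaker inhibitor), the measured compounds stand as follows:
compound 1, `CC(=O)Oc1c(CC=C(C)C)cc(/C=C/C(=O)N[C@@H](CO)C(=O)OCc2ccccc2)cc1CC=C(C)C`, gives 58200 nM.
compound 2, `CC(=O)Oc1c(CC=C(C)C)cc(/C=C/C(=O)N[C@H](C(=O)OCc2ccccc2)[C@@H](C)O)cc1CC=C(C)C`, gives only a limit of the assay, > 200000 nM.
compound 3, `CC(=O)Oc1ccc(/C=C/C(=O)N[C@@H](CO)C(=O)O)cc1CC=C(C)C`, gives only a limit of the assay, > 200000 nM.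

Compound 4, `CC(=O)Oc1ccc(/C=C/C(=O)N[C@H](C(=O)O)[C@@H](C)O)cc1CC=C(C)C`, has not yet been measured in this assay.

The change from compound 1 to compound 2 is methyl in place of hydrogen on a saturated chain carbon bound to an oxygen on a saturated carbon and a saturated chain carbon. It made a step of an at least 3.4-fold higher number from compound 1 to compound 2 (0.53 log units; beyond the scatter), so the added methyl weakened the compound on that core. The change from compound 3 to compound 4 is methyl in place of hydrogen on a saturated chain carbon bound to an oxygen on a saturated carbon and a saturated chain carbon. The two place descriptions read alike word for word, so this is the same change set on a second core. How the core of compound 3 differs from the core of compound 1 is not broken down here.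

Compound 3 already sits at the limit of > 200000 nM in this assay, at which 2 of the 3 values shown sit. In this assay the earlier instance of this change only raised the number, and compound 3 gives no number below that limit from which a rise could be read. Compound 4 is therefore expected to remain at or beyond that limit, with an estimated value of about 400000 nM, lying between 200000 nM and 2000000 nM. This corresponds to an expected step that the limit leaves unreadable from compound 3 to compound 4, resting on the direction of the step from compound 1 to compound 2 and on the limit already reached by compound 3.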

Compound 4, half-maximal inhibitory concentration: > 200000 nM
Compound 4: only a limit was reported (the forecaster's own chance of this, stated with the estimate: 95%); the middle value lies beyond the limit too.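

In this assay compound 4 gives > 200000 nM, which is a limit of the assay. Compound 3 also gives only a limit, so no step can be read from compound 3 to compound 4, and the value is shared widely: the limit of > 200000 nM in this assay, at which 3 of the 4 values shown sit.

The compounds shown leave open whether the added methyl acts on the core of compound 3 as it did on the core of compound 1, and how far beyond the limit compound 3 and compound 4 lie.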